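The compounds below may be only part of what the source reports. "The series", "measured", "known", "first", "only" and "open" are said of these compounds alone.

Working notes on the series in an ADME assay on Huh-7 cells (Homo sapiens) for cytotoxicity, with a stated time of 72 h; on this read-out lower numbers stand for higher toxicity in this test and higher numbers for lower toxicity in this test. Compound 1 (`CS(=O)(=O)Nc1ccc2c(c1)S(=O)(=O)N=C(c1c(O)c(-c3ccsc3)nn(CCC3CC3)c1=O)N2`) gives only a limit, > 1000 nM. Compound 2 (`CCC(C)(C)Cn1nc(-c2cccs2)c(O)c(C2=NS(=O)(=O)c3cc(NS(C)(=O)=O)ccc3N2)c1=O`) also gives only a limit, > 1000 nM. Compound 3 (`CCC(C)CCn1nc(-c2cccs2)c(O)c(C2=NS(=O)(=O)c3cc(NS(C)(=O)=O)ccc3N2)c1=O`) likewise gives only a limit, > 1000 nM, so it has no number of its own on this read-out.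

The next compound is compound 4 (`CS(=O)(=O)Nc1ccc2c(c1)S(=O)(=O)N=C(c1c(O)c(-c3cccs3)nn(CCC3CC3)c1=O)N2`). The change reads (cyclopropyl in place of sec-butyl on a saturated chain carbon, two bonds along the chain from an aromatic nitrogen), with cyclopropyl in place of sec-butyl on a saturated chain carbon, two bonds along the chain from an aromatic nitrogen.

Among the measured compounds shown here, the one measured step that bears on this change, a step that the two limits leave unreadable from compound 2 to compound 3, also alters the group on the aromatic nitrogen, but it has no readable size. The remaining evidence is the limit of > 1000 nM in this assay, at which 3 of the 3 values shown sit. No step beyond the usual scatter is therefore expected, and no direction can be assigned. The expected change is a step that the limit leaves unreadable from compound 3 to compound 4, an estimate that starts from a limit and not from a measured number. Compound 4 is expected to read 3000 nM, within an estimated range of 1000 nM to 20000 nM.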

Compound 4, half-maximal cytotoxic concentration: > 33000 nM
Compound 4 gave a limit, no number; the forecaster's own chance of this, stated with the estimate: 90%; at least 11-fold (1.04 log units) between middle value and limit.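

Compound 4, like compound 1, compound 2 and compound 3, gives only a limit in this assay, so no step among these compounds can be read. The compounds shown leave open where any of them would reach a half-maximal cytotoxic concentration, and whether the changes in chain or thiophenyl group shift it.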